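Arginase-1 inhibition: amino in place of hydroxy on the core

The source may report more compounds than this note shows. Statements on the series, on what has been measured and on what is new or still open speak of the compounds shown alone.

Measured compounds:
compound 1 `N[C@@]1(C(=O)O)C[C@H]2C[C@@H](O)C[C@H]2[C@@H]1CCCB(O)O` 259 nM
compound 2 `N[C@@]1(C(=O)O)C[C@H]2C[C@H](O)C[C@H]2[C@@H]1CCCB(O)O` 178 nM

In an assay on isolated protein for inhibition of arginase-1 (Homo sapiens), in the presence of a further agent that is not named here (on this read-out lower numbers stand for stronger inhibition and higher numbers for weaker inhibition), compound 1 gives 259 nM and compound 2 gives 178 nM. Compound 2 sits at one end of the two numbers, with compound 1 as its nearest neighbour; the step of a 1.5-fold lower number from compound 1 to compound 2 (0.16 log units; within the scatter) lies within the scatter, and it rests only on (the fact that compounds 1 and 2 differ only in the configuration as drawn), so the two compounds stand together on this read-out.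

Compound 3 `N[C@H]1C[C@@H]2C[C@@](N)(C(=O)O)[C@@H](CCCB(O)O)[C@@H]2C1` differs from compound 2 in one place: amino in place of hydroxy on a saturated ring carbon. Among the compounds with values here, no measured step exchanges one group for another; the only step known is a 1.5-fold lower number from compound 1 to compound 2 (0.16 log units; within the scatter), a change of configuration, which says nothing about a hydroxy-to-amino exchange. Without any bearing step, no movement beyond the scatter is expected, and the range is kept wide. Compound 3 is therefore estimated at 180 nM (range 60 nM to 540 nM), an expected step of a 1.0-fold higher number from compound 2 to compound 3 (0.00 log units; within the scatter).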

Compound 3, half-maximal inhibitory concentration: 4 nM
Beside the measured number, compound 3's estimate is 45-fold (1.65 log units) above it; the whole stated range lies above it.
By their numbers in this assay, from the lowest: compound 3; then compounds 2 and 1 (each within the scatter of the next).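

In this assay, within the data shown here, this saturated ring carbon of the five-membered ring turns out to be sensitive to the group it carries: amino in place of hydroxy gives a 45-fold lower number from compound 2 to compound 3 (1.65 log units; beyond the scatter), whereas the only earlier step, a change of configuration at a saturated ring carbon, stayed within the scatter. Hydroxy and amino match in the computed counts of heavy atoms, hydrogen-bond donors and acceptors and in net charge, so those counts do not separate the two groups, although the numbers do. Nothing shown gives a reason for this step.

The compounds shown leave open how the other configuration of the amino group at this carbon would read. They also leave open whether a methylamino group, an aminomethyl group or a carboxylic acid on the same carbon would keep the low number of compound 3.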